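The compounds below may be only part of what the source reports. "The series", "measured", "known", "first", "only" and "open" are said of these compounds alone.

Working notes on the series. Three compounds carry numbers in a physicochemical assay for lipophilicity, at pH 7.4; on this read-out lower numbers stand for lower lipophilicity and higher numbers for higher lipophilicity. Compound 1 `CCc1ccc(N(CC(C)C)S(=O)(=O)c2ccc3c(c2)C(OC2CCCCC2)CC(C2CCOCC2)O3)cc1` gives 6.28 in this assay, the highest of the three. Compound 3 `Cc1ccc(N(C2CCC2)S(=O)(=O)c2ccc3c(c2)C(O)CC(C2CCOCC2)O3)c(C)c1` stands nearest to it with 3.77, and compound 2 `CCc1ccc(NS(=O)(=O)c2ccc3c(c2)C(O)CC(C2CCOCC2)O3)cc1` stands furthest with 2.59; both gaps to compound 1 lie beyond the scatter. Among the measured compounds shown here, no single-point step between measured compounds exists, so only the two values of each pair can be compared. Compound 4 `CCc1ccc(N(CC(C)C)S(=O)(=O)c2ccc3c(c2)C(C)CC(C2CCOCC2)O3)cc1` has not been measured. It differs from compound 1 in one place: methyl in place of cyclohexyloxy on a saturated ring carbon. The step from compound 1 is expected to be a decrease beyond the scatter, a number 1.68 log units lower from compound 1 to compound 4 (beyond the scatter). Compound 4 is expected to give 4.6 in this assay, within a range from 3.9 to 5.4.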

Compound 4, distribution coefficient: 5.71
Compound 4: middle estimate off by 1.11 log units, on the low side; the whole stated range lies below it.
By their numbers in this assay, from the lowest: compound 2; then compound 3; then compound 4; then compound 1.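

Methyl in place of cyclohexyloxy on this saturated ring carbon gives a number 0.57 log units lower from compound 1 to compound 4 (beyond the scatter) in this assay, the first change in the series that can be read at a single place. Seven heavy atoms, a carbon-only ring and a hydrogen-bond acceptor leave together here, so this one step cannot separate their contributions. No measurement shown accounts for the size of this step.

From the compounds shown here alone, how an amine, a carboxylic acid or a longer chain on this ring carbon would read in this assay remains open.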